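A few compounds are considered here, and "the series" means these few. Any claim that something is new, unique, unknown or untested is made for them only; others in the source may bear on it.

Working notes on the series in a functional assay on PC-3 cells (Homo sapiens) for cytotoxicity, read by MTT assay, with a stated time of 48 h; a lower number here means a stronger inhibitor, a higher number a weaker inhibitor.

Compound 1 `[O-][n+]1nc(NCc2ccccc2Cl)[n+]([O-])c2ccccc21` gives 10600 nM in this assay. Compound 2 `CCNc1n[n+]([O-])c2ccccc2[n+]1[O-]` gives 13300 nM; the step of a 1.3-fold higher number from compound 1 to compound 2 (0.10 log units; within the scatter) sits within the scatter, so the two are not separated. Compound 3 `CCN(CC)c1n[n+]([O-])c2ccccc2[n+]1[O-]` reaches only the limit > 107000 nM in this assay, a limit and not a number. The step of an at least 8.0-fold higher number from compound 2 to compound 3 (0.90 log units; beyond the scatter) is beyond the scatter, in keeping with the limit of > 107000 nM in this assay, at which 1 of the 3 values shown sits.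

Among the two numbers shown, compound 2 stands highest, with compound 1 a small distance away within the scatter.

Compound 4 `[O-][n+]1nc(Nc2ccccc2)[n+]([O-])c2ccccc21` differs from compound 2 by phenyl in place of ethyl on a nitrogen on an aromatic ring; the hydrogen on that nitrogen is kept. Going by the values given here, the only step that bears on a change at this nitrogen, from compound 2 to compound 3, involved a hydrogen replaced by ethyl, which is not the change here; the step from compound 1 to compound 2, a change on the carbon next to the nitrogen, was within the scatter. A small step of a 1.5-fold lower number from compound 2 to compound 4 (0.17 log units; within the scatter) is therefore expected, with no direction secured beyond the scatter. Compound 4 is estimated at 9000 nM, within 3000 nM to 30000 nM.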

Compound 4, half-maximal inhibitory concentration: 17000 nM
The estimate for compound 4 lay 1.9-fold (0.28 log units) below the measured number, within the range that was stated.
By their numbers in this assay, from the lowest: compounds 1, 2 and 4 (each within the scatter of the next). At a limit, above all of these: compound 3.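

The step of a 1.3-fold higher number from compound 2 to compound 4 (0.11 log units; within the scatter) shows that in this assay phenyl and ethyl are not separated on this nitrogen while its hydrogen is kept. The earlier compounds shown here showed a change on the chain carbon bound to this nitrogen, not a ring placed directly on the nitrogen, so tolerance here now extends to a six-membered aromatic ring of carbon only. Compound 3, which carries a second ethyl in place of that hydrogen, stands at a limit and not a number: the limit of > 107000 nM in this assay, at which 1 of the 4 values shown sits.

Open, as far as these compounds go, is how a longer chain, or a chain ending in an amine or a carboxylic acid, would read on this nitrogen with the hydrogen kept. Also open, from the compounds shown here alone, is whether the separation at compound 3 follows the loss of that hydrogen or the second ethyl itself, a question that a single pair cannot settle.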